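From Carboxy to Methoxycarbonyl on a Shared Core

This account rests on a few compounds, and the source may have more. Where it says the series, first, only, none or still open, it means among the compounds named here.

Compound 2 `CN(/N=C/c1cccc(C(=O)O)c1)C(=O)c1ccc(N(C)C)cc1` gives > 67000 nM in a physicochemical assay for solubility, read by spectrophotometry, with a stated time of 24 h, at pH 7.4 (on this read-out higher numbers stand for higher solubility and lower numbers for lower solubility), and this value is a limit of the assay, not a number. Compound 1 `COC(=O)c1cccc(/C=N/NC(=O)c2ccc(N(C)C)cc2)c1` gives 3700 nM in this assay. Compound 3 `COC(=O)c1cccc(/C=N/N(C)C(=O)c2ccc(N(C)C)cc2)c1` turns the carboxy of compound 2 into methoxycarbonyl, with methyl in place of hydrogen on an oxygen next to a carbonyl group. Compound 1 also carries methoxycarbonyl and stands at 3700 nM, which is the ground for expecting a fall. The expected step is an at least 9.5-fold lower number from compound 2 to compound 3 (0.98 log units; beyond the scatter), a drop beyond the usual scatter. For compound 3 the estimated value is 7000 nM, with an expected range from 1500 nM to 30000 nM.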

Compound 3, solubility: 8200 nM
For compound 3 the middle estimate is 1.2-fold (0.07 log units) below the measured one; low and high end bracket the measured number.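

The change from carboxy to methoxycarbonyl on the shared core comes with an at least 8.1-fold lower number from compound 2 to compound 3 (0.91 log units; beyond the scatter). The value for compound 2 is a limit of the assay, not a number, so this step has a floor but no exact size: the limit of > 67000 nM in this assay, at which 1 of the 3 values shown sits. The methoxycarbonyl series also gains a second comparison, as methyl in place of hydrogen on an amide-type nitrogen comes with a 2.2-fold higher number from compound 1 to compound 3 (0.35 log units; beyond the scatter).

The compounds shown leave open how a carboxamide or an ethyl ester in place of methoxycarbonyl would read. From the compounds shown here alone, the true distance between compound 2 and compound 3 also stays open.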